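Isopropyl in Place of Hydrogen on a Core Without Readable Potency

The compounds below may be only part of what the source reports. "The series", "measured", "known", "first", "only" and "open" are said of these compounds alone.

Measured in a functional assay for inhibition, with Homo sapiens as the target; a lower number here means a stronger inhibitor, a higher number a weaker inhibitor:
Compound 1, `CCCc1nc(C)c2c(CC)nnc(SC)n12`, gives > 48000 nM, which is a limit of the assay and not a number.
Compound 2, `CCCc1nc(C)c2cnnc(SCC(=O)OCC)n12`, gives > 48000 nM, again a limit of the assay.
Compound 3, `CCCc1nc(C)c2cnnc(SC)n12`, gives > 48000 nM, also a limit of the assay.

Compound 3 therefore stands exactly where the other two stand: at the limit of > 48000 nM in this assay, at which 3 of the 3 values shown sit. No measured step can be read in size. The change from ethyl to hydrogen on an aromatic carbon, a step that the two limits leave unreadable from compound 1 to compound 3, is unreadable, and so is the removal of ethoxycarbonyl from the saturated chain carbon bound to sulfur, a step that the two limits leave unreadable from compound 2 to compound 3.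

Compound 4, `CCCc1nc(C)c2c(C(C)C)nnc(SC)n12`, differs from compound 3 by isopropyl in place of hydrogen on an aromatic carbon. Among the measured compounds shown here, the only measured step that touches the same aromatic carbon is the one from compound 1 to compound 3, and that step is unreadable, so it gives no size and no direction to carry over. The expectation is that the step that the limit leaves unreadable from compound 3 to compound 4 will not be readable either, with compound 4 most likely returning another limit in this assay. Compound 4 is estimated at 70000 nM, within a range from 20000 nM to 250000 nM.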

Compound 4, half-maximal inhibitory concentration: > 48000 nM
Compound 4: a limit, no number; the forecaster's own chance of this, stated with the estimate: 85%; the middle value is on the limit's open side.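

Compound 4 again returns a limit of the assay and not a number, so its steps from compound 3 and from compound 1 cannot be read in size. In this assay the compounds shown leave open whether any change on the shared core gives a readable number.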